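This account rests on a few compounds, and the source may have more. Where it says the series, first, only, none or still open, it means among the compounds named here.

Working notes on the series. Three compounds have so far been run in an assay on CHO cells for positive allosteric modulation of metabotropic glutamate receptor 5 (Homo sapiens), read by FLIPR; a higher number here means that more compound is needed for the effect, a lower number that less compound is needed. Compound 1 `Cc1ccc2c(c1C)C(=O)N(Cc1cc(Br)ccc1NC(=O)c1ccccn1)C2=O` gives only a limit in this assay, recorded as > 100000 nM. Compound 2 `O=C(Nc1ccc(Br)cc1CN1C(=O)c2ccc(F)cc2C1=O)c1ccccn1` gives a measured number, 930 nM in this assay. Compound 3 `O=C(Nc1ccc(Cl)cc1CN1C(=O)c2ccccc2C1=O)c1ccccc1`, the starting point of the step followed here, also gives only a limit, > 100000 nM in this assay. Compound 3 therefore stands with no number of its own at the limit of > 100000 nM in this assay, at which 2 of the 3 values shown sit, and compound 2 alone among the three carries a measured half-maximal effective concentration.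

Compound 4 `O=C(Nc1ccc(Cl)cc1CN1C(=O)c2ccccc2C1=O)c1cccnn1` is the next compound and has not been measured. It differs from compound 3 in one place: pyridazin-3-yl in place of phenyl on a carbonyl carbon. Compound 3 carries a phenyl on the carbonyl carbon and gives no number. Compound 2 carries a pyridyl on its carbonyl carbon and gives 930 nM in this assay, which is the only pointer toward what an aromatic ring with ring nitrogen on that carbonyl carbon may do here. On that basis a gain beyond the scatter is expected for compound 4, a step of an at least 25-fold lower number from compound 3 to compound 4 (1.39 log units; beyond the scatter), though the chance that compound 4 again returns only a limit stays real. Compound 4 is estimated at 4000 nM in this assay, with a range from 800 nM to 60000 nM.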

Compound 4, half-maximal effective concentration: > 100000 nM
Compound 4: only a limit was reported; the forecaster's own chance of this, stated with the estimate: 40%; at least 25-fold (1.39 log units) between middle value and limit.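

In this assay, within the data shown here, compound 4 returns only a limit, > 100000 nM, and compound 3 is also held at a limit, so no step from compound 3 to compound 4 can be read. The compounds shown leave open whether pyridazin-3-yl in place of phenyl on a carbonyl carbon changes the half-maximal effective concentration at all.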